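A few compounds are considered here, and "the series" means these few. Any claim that something is new, unique, unknown or untested is made for them only; others in the source may bear on it.

Measured compounds, with their partition coefficients:

- Compound 1, `CCCCCc1nc2ccccc2[nH]1`: 3.43
- Compound 2, `CCCCCCCCc1nc2ccccc2[nH]1`: 4.93
- Compound 3, `CCCCc1nc2cc(C)c(C)cc2[nH]1`: 3.9

In a physicochemical assay for lipophilicity (a lower number here means a more polar compound, a higher number a more lipophilic compound), compound 2 stands at the top of the three, compound 1 at the bottom, and compound 3 lies between them, higher than compound 1 and lower than compound 2. Among the measured compounds shown here, the one step that can be counted within a single change is a number 1.50 log units higher from compound 1 to compound 2 (beyond the scatter), the change being (propyl in place of hydrogen on a saturated chain carbon, five bonds along the chain from an aromatic carbon). How the core of compound 3 differs from the core of compound 1 is not broken down here; the two differ in more than one place.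

Compound 4, `CCCCCCCc1nc2cc(C)c(C)cc2[nH]1`, is not yet measured in this assay. It arises from compound 3 by propyl in place of hydrogen on a saturated chain carbon, four bonds along the chain from an aromatic carbon. For the measured compounds named here, this is the same kind of change as the one from compound 1 to compound 2, not the same: in compound 4 the propyl enters on a saturated chain carbon four bonds along the chain from an aromatic carbon, whereas in compound 2 it enters five bonds along the chain from an aromatic carbon. A step of about the same size is expected for compound 4, because the only measured case of this kind of change is a number 1.50 log units higher from compound 1 to compound 2 (beyond the scatter), which is beyond the scatter and large; the expected step from compound 3 to compound 4 is a number 1.50 log units higher from compound 3 to compound 4 (beyond the scatter). Compound 4 is therefore estimated at 5.4, with a range from 5 to 5.8.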

Compound 4, partition coefficient: 5.4
The estimate for compound 4 equals the measured number at the digits printed; measured number inside the range.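

In this assay, propyl in place of hydrogen gives a number 1.50 log units higher from compound 3 to compound 4 (beyond the scatter) and, on the core of compound 1, gives a number 1.50 log units higher from compound 1 to compound 2 (beyond the scatter) as well, so the two steps match at the digits printed even though the propyl enters four bonds along the chain from an aromatic carbon in compound 4 and five bonds along in compound 2. This shows that the change carried over between these two cores without a visible loss or gain in step size, but it rests on two pairs only, both with a saturated chain, and it sets no rule for other cores, other chain lengths or other places on the chain. Nothing at hand accounts for the size of the step or for its agreement between the two cores.

The compounds shown leave open whether a longer chain than those here, or a chain ending in an amine or a carboxylic acid, would follow the same step. They also leave open how much each difference between the core of compound 1 and the core of compound 3 contributes, as those two compounds differ in more than one place.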